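This account rests on a few compounds, and the source may have more. Where it says the series, first, only, none or still open, it means among the compounds named here.

The measured compounds:
- compound 1, `COc1cc(/C=C/C(=O)c2cccc(-n3cc(-c4ccc(Cl)cc4)[nH]c3=O)c2)cc(OC)c1OC`, which in a functional assay on NCI-H23 cells (Homo sapiens) for inhibition (a lower number here means a stronger inhibitor of growth, a higher number a weaker inhibitor of growth), gives 3560 nM
- compound 2, `O=C(/C=C/c1cccc(O)c1)c1cccc(-n2cc(-c3ccc(Cl)cc3)[nH]c2=O)c1`, which in this assay gives 2780 nM
- compound 3, `COc1cc(/C=C/C(=O)c2cccc(-n3cc(-c4ccccc4)[nH]c3=O)c2)cc(OC)c1OC`, which in this assay gives 1430 nM

Compound 3 has the lowest of the three numbers in this assay. Its gap to compound 2 lies within the scatter, so the two values do not separate the compounds. Its gap to compound 1 is a measured step, a 2.5-fold lower number from compound 1 to compound 3 (0.40 log units; beyond the scatter), and that step is beyond the scatter.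

Compound 4, `COc1cc(/C=C/C(=O)c2cccc(-n3cc(-c4cc(OC)c(OC)c(OC)c4)[nH]c3=O)c2)cc(OC)c1OC`, differs from compound 3 in one place: 3,4,5-trimethoxyphenyl in place of phenyl on an aromatic carbon. For the measured compounds named here, the single measured step, a 2.5-fold lower number from compound 1 to compound 3 (0.40 log units; beyond the scatter), concerns a different exchange at that place, chloro against hydrogen, and it tells nothing direct about three methoxy groups entering there. Going by the values given here, no other measured pair bears on this change. The expectation therefore rests on little: compound 4 is estimated to sit near compound 3, with a step of a 1.0-fold higher number from compound 3 to compound 4 (0.02 log units; within the scatter) that is not expected to go clearly beyond the scatter in either direction. The estimate for compound 4 in this assay is 1500 nM, with a range from 500 nM to 5000 nM.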

Compound 4, concentration for 50% growth inhibition: 2000 nM
Compound 4: middle estimate off by 1.3-fold (0.12 log units), on the low side; low and high end bracket the measured number.
By their numbers in this assay, from the lowest: compounds 3, 4, 2 and 1 (each within the scatter of the next, the first and the last beyond it).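

In this assay, putting 3,4,5-trimethoxyphenyl in place of phenyl on the aromatic carbon of the five-membered ring gives a 1.4-fold higher number from compound 3 to compound 4 (0.15 log units; within the scatter) and so does not separate the two compounds, even though the entering group brings 12 heavy atoms in place of 6 and 3 hydrogen-bond acceptors where phenyl has none. For the compounds shown here, the same place, with 3,4,5-trimethoxyphenyl in place of 4-chlorophenyl, gives a 1.8-fold lower number from compound 1 to compound 4 (0.25 log units; within the scatter), so compound 4 stands apart from neither compound 1 nor compound 3, although those two differ from each other beyond the scatter, and the earlier step between chloro and hydrogen therefore finds no counterpart with the three methoxy groups. Nothing at hand explains why this large exchange at this place leaves the growth-inhibition number so little moved.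

The compounds shown carry only substituted or plain phenyl at this place, so it remains open what an amine, a carboxylic acid or a longer chain on that ring would do to the number. Going by these compounds, it also remains open whether a single methoxy group there, or a pyridine ring in place of the phenyl, would give a step that goes beyond the scatter.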